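Biaryl Extension of a Nitroimidazole Urea: Solubility Outlook

The compounds below may be only part of what the source reports. "The series", "measured", "known", "first", "only" and "open" are said of these compounds alone.

Among the compounds with values here, compound 1 `O=C(NCc1ccc(OC(F)(F)F)cc1)N[C@@H]1COc2nc([N+](=O)[O-])cn2C1` is one of two compounds measured in a physicochemical assay for solubility, read by HPLC, measured as kinetic solubility, at pH 7 (on this read-out higher numbers stand for higher solubility and lower numbers for lower solubility), and in this assay compound 1 gives 32 ug/mL. Its companion, compound 2 `O=C(NCc1ccc(OC(F)(F)F)cc1)O[C@@H]1COc2nc([N+](=O)[O-])cn2C1`, shares the same core and the same trifluoromethoxy-bearing benzyl group, and in this assay compound 2 gives 10 ug/mL. Of the two numbers, that of compound 1 is the higher, and the gap between them lies beyond the usual scatter of repeated measurements, so compound 1 stands as the more soluble of the pair on the evidence at hand.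

Compound 3 `O=C(NCc1ccc(-c2ccc(OC(F)(F)F)cc2)cc1)N[C@@H]1COc2nc([N+](=O)[O-])cn2C1` has not yet been measured. It differs from compound 1 in a single place: 4-(trifluoromethoxy)phenyl in place of trifluoromethoxy on an aromatic carbon. Within the data shown here, no measured pair shows this change, so its effect has to be guessed. The account expects a step downward in this assay, a step that is clearly larger than the scatter, with the estimated step of an 8.0-fold lower number from compound 1 to compound 3 (0.90 log units; beyond the scatter). On this basis compound 3 is expected to give about 4 ug/mL, with a plausible range from 1 ug/mL to 15 ug/mL.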

Compound 3, solubility: 0.94 ug/mL
For compound 3 the middle estimate is 4.3-fold (0.63 log units) above the measured one; measured number outside the range, below it.
By their numbers in this assay, from the lowest: compound 3; then compound 2; then compound 1.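

In this assay, within the data shown here, the earlier compounds both carried the same trifluoromethoxy-bearing benzyl group and so showed nothing about this position; the first reading of it is a 34-fold lower number from compound 1 to compound 3 (1.53 log units; beyond the scatter), a large step on going from trifluoromethoxy to 4-(trifluoromethoxy)phenyl on an aromatic carbon. The group that enters brings one more six-membered aromatic ring of carbon only, while the hydrogen-bond donor and acceptor counts of the two groups match and neither carries a net charge, so in this single pair a large step comes with no change in those counts. Nothing measured alongside this pair bears on what lies behind the step.

A single pair cannot separate the added ring from the larger size of the group, and it does not tell whether the same change would give a step of similar size on the carbamate compound 2. Going by these compounds, how the extended compound would read in this assay with an amine or a carboxylic acid in place of the trifluoromethoxy on the added ring also stays open.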